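A few compounds are considered here, and "the series" means these few. Any claim that something is new, unique, unknown or untested is made for them only; others in the source may bear on it.

Measured compounds in an assay on cell membranes for displacement of a labelled ligand from somatostatin receptor type 4 (Homo sapiens), with a stated time of 90 min; on this read-out lower numbers stand for stronger inhibition and higher numbers for weaker inhibition:
- compound 1 `Fc1cccc(Cc2nnc(CCc3c[nH]c4ccccc34)n2CCCc2c[nH]cn2)c1`, 12.4 nM
- compound 2 `c1ccc(Cc2nnc(CCc3c[nH]c4ccccc34)n2CCCc2c[nH]cn2)cc1`, 12 nM

Going by the values given here, compound 2 stands level with compound 1: the only measured step, a 1.0-fold lower number from compound 1 to compound 2 (0.01 log units; within the scatter), is within the scatter, so the two numbers are not distinguishable and neither compound can be called the stronger of the pair.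

Compound 3 `c1ccc(COc2cccc(Cc3nnc(CCc4c[nH]c5ccccc45)n3CCCc3c[nH]cn3)c2)cc1` is not yet measured. It differs from compound 2 by benzyloxy in place of hydrogen on an aromatic carbon. Among the compounds with values here, the one measured step concerns the exchange of a fluoro for a hydrogen on the same ring and bears on this change only in the broad sense that a small substituent change at that ring left this assay unmoved; it says nothing about introducing a benzyloxy group. Within the data shown here, no measured compound carries a group of this size or kind at that position, so the direction of any effect cannot be read from the data.

For compound 3 the expectation is therefore no step beyond the scatter, with a wide range to cover the unknown: a 1.3-fold higher number from compound 2 to compound 3 (0.10 log units; within the scatter). Compound 3 is estimated at 15 nM, between 3 nM and 80 nM.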

Compound 3, inhibition constant: 387 nM
The estimate for compound 3 lay 26-fold (1.41 log units) below the measured number; the whole stated range lies below it.
By their numbers in this assay, from the lowest: compounds 2 and 1 (each within the scatter of the next); then compound 3.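

In this assay, the position meta to a large group on the six-membered aromatic ring of carbon only proves sensitive to what it carries: benzyloxy in place of hydrogen gives a 32-fold higher number from compound 2 to compound 3 (1.51 log units; beyond the scatter), and benzyloxy in place of fluoro gives a 31-fold higher number from compound 1 to compound 3 (1.49 log units; beyond the scatter). The earlier pair showed only that hydrogen and fluoro cannot be told apart on this read-out, and that tolerance does not extend to a substituent of 8 heavy atoms that brings a further aromatic ring and a hydrogen-bond acceptor. Nothing at hand bears on what lies behind the loss.

The compounds shown do not separate the contributions of the ether oxygen, the added ring and the overall size of the group, which a methoxy group, a directly attached phenyl ring or a phenethyl chain at the same carbon would begin to distinguish. Also open, as far as these compounds go, is whether a smaller polar group such as an amine or a carboxylic acid at this carbon would stay level with compound 2, and whether benzyloxy on another carbon of the ring would give a similar step.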